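Compound 4 against three assay limits

A few compounds are considered here, and "the series" means these few. Any claim that something is new, unique, unknown or untested is made for them only; others in the source may bear on it.

Measured so far:
- compound 1 `Cn1c(-c2ccc(-c3cncnc3)cc2)nnc1C1(c2ccc(Cl)cc2)CCC1`: > 4000 nM in an assay on isolated protein for inhibition of 11-beta-hydroxysteroid dehydrogenase type 2 (Mus musculus); on this read-out higher numbers stand for weaker inhibition and lower numbers for stronger inhibition
- compound 2 `Cn1c(-c2ccc(C(=O)NC(C)(C)C)cc2)nnc1C1(c2ccc(Cl)cc2)CCC1`: > 4000 nM
- compound 3 `Cn1c(-c2ccc(C(=O)NC3CC3)cc2)nnc1C1(c2ccc(Cl)cc2)CCC1`: > 4000 nM

Each of these three values is a limit of the assay, not a number. Compound 3 therefore stands at that limit, and the other two values shown sit at the same limit, so compound 3 cannot be placed above or below either of them (the limit of > 4000 nM in this assay, at which 3 of the 3 values shown sit). The steps among the measured compounds, a step that the two limits leave unreadable from compound 1 to compound 2, a step that the two limits leave unreadable from compound 1 to compound 3 and a step that the two limits leave unreadable from compound 2 to compound 3, are all left unreadable by the limits.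

Compound 4 `Cc1noc(C)c1-c1ccc(-c2nnc(C3(c4ccc(Cl)cc4)CCC3)n2C)cc1` differs from compound 3 as follows: 3,5-dimethyl-1,2-oxazol-4-yl in place of cyclopropylcarbamoyl on an aromatic carbon. The step most akin to this one runs between compound 3 and compound 1, where an aromatic heterocycle also occupies that carbon, and compound 1 likewise gives only a limit. Among the compounds with values here, no measured step offers a readable size, so no direction can be read from them; compound 4 is expected to return a limit again, with a step that the limit leaves unreadable from compound 3 to compound 4 as the estimated step. The estimate for compound 4 is 8000 nM, expected between 2000 nM and 30000 nM.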

Compound 4, half-maximal inhibitory concentration: > 4000 nM
Compound 4 ended at the assay's limit; the forecaster's own chance of this, stated with the estimate: 80%; the middle value lies beyond the limit too.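

No new step can be read among compound 1, compound 2, compound 3 and compound 4, as each value is a limit and not a number: the limit of > 4000 nM in this assay, at which 4 of the 4 values shown sit.

The compounds shown leave open how strongly any of the four inhibits in this assay, and whether any exchange of these groups changes that inhibition.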